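The source may hold more compounds than are shown below. What is called first, only, known or untested is meant among the compounds shown, and "the series" means these compounds.

Working notes on the series. In a functional assay on HCT-116 cells (Homo sapiens) for inhibition, read by sulforhodamine B assay, with a stated time of 48 h, tested at 50 uM (a lower number here means less inhibition of growth, a higher number more inhibition of growth at the concentration tested), compound 1 (`COc1cccc(/C=C/C(=O)/C=C/c2ccc(OCc3cn(CCCCOc4cc(=O)oc5ccccc45)nn3)c(OC)c2)c1`) gives 44%. Compound 2 (`COc1ccc(/C=C/C(=O)/C=C/c2ccc(OCc3cn(CCCCCOc4cc(=O)oc5ccccc45)nn3)c(OC)c2)cc1`) gives 35%, within the scatter of compound 1. Compound 3 (`COc1ccc(/C=C/C(=O)/C=C/c2ccc(OCc3cn(CCCOc4cc(=O)oc5ccccc45)nn3)c(OC)c2)cc1OC`) gives 67%, beyond the scatter and higher than compound 1. Compound 1 therefore stands level with compound 2 and clearly under compound 3. Among the compounds with values here, these three compounds differ in more than one place, so no measured pair isolates a single change.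

Compound 4 (`COc1cc(/C=C/C(=O)/C=C/c2cccs2)ccc1OCc1cn(CCCCOc2cc(=O)oc3ccccc23)nn1`) carries thiophen-2-yl in place of 3-methoxyphenyl on a double-bonded chain carbon bound to a double-bonded chain carbon, compared with compound 1 (thiophen-2-yl in place of 3-methoxyphenyl on a double-bonded chain carbon bound to a double-bonded chain carbon). Within the data shown here, the measured compounds offer no direct precedent for this replacement, so no step beyond the scatter, in either direction, is expected in this assay. The estimated change is a number 1 percentage points lower from compound 1 to compound 4 (within the scatter). The estimate is anchored on compound 1 at 44%, and the range is kept wide for lack of a matched pair. For compound 4 the estimated value is 43%, with an expected range from 27% to 60%.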

Compound 4, percent growth inhibition at one concentration: 41%
For compound 4 the middle estimate is 2 percentage points above the measured one; the measured number falls inside the stated range.
By their numbers in this assay, from the lowest: compounds 2, 4 and 1 (each within the scatter of the next); then compound 3.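

Within the data shown here, the first step that isolates a single change comes with thiophen-2-yl in place of 3-methoxyphenyl on a double-bonded chain carbon bound to a double-bonded chain carbon: in this assay it reads a number 3 percentage points lower from compound 1 to compound 4 (within the scatter) for this replacement. At this place, a group of 5 heavy atoms with a five-membered aromatic ring therefore stands level with one of 8 heavy atoms with a six-membered aromatic ring of carbon only. Nothing available explains this result.

The pair leaves open whether the same replacement stays within the scatter with the other linker lengths or alongside the rest of compound 3. Also open, from the compounds shown here alone, is what a pyridin-3-yl or a 4-(dimethylamino)phenyl group would give at this place.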